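The source may hold more compounds than are shown below. What is called first, only, known or untested is meant among the compounds shown, and "the series" means these compounds.

Working notes on the series. In a functional assay on MDA-MB-436 cells (Homo sapiens) for antiproliferative activity, read by MTT assay, with a stated time of 48 h (on this read-out lower numbers stand for stronger inhibition and higher numbers for weaker inhibition), compound 1 (`CN1CCN(c2ccc(-c3cc4c(N5CCN(C(=O)Nc6ccccc6)CC5)ncnc4s3)cc2)CC1`) gives 7090 nM, compound 2 (`CN1CCN(c2ccc(-c3cc4c(N5CCN(C(=O)Nc6ccc(F)cc6F)CC5)ncnc4s3)cc2)CC1`) gives 20200 nM and compound 3 (`CC(C)c1cccc(C(C)C)c1NC(=O)N1CCN(c2ncnc3sc(-c4ccc(N5CCN(C)CC5)cc4)cc23)CC1`) gives 11300 nM. Compound 3 holds the middle of these three numbers, and its gaps to both others stay within the scatter.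

Compound 4 (`CN1CCN(c2ccc(-c3cc4c(N5CCN(C(=O)Nc6cc(C(F)(F)F)ccc6F)CC5)ncnc4s3)cc2)CC1`) carries one change from compound 3: 2-fluoro-5-(trifluoromethyl)phenyl in place of 2,6-diisopropylphenyl on an amide-type nitrogen. This places 2-fluoro-5-(trifluoromethyl)phenyl in place of 2,6-diisopropylphenyl on an amide-type nitrogen.

All three measured steps bear on this, since each swaps the group at that same place. The largest is a 2.8-fold higher number from compound 1 to compound 2 (0.45 log units; beyond the scatter), which is modest. The other two are a 1.6-fold higher number from compound 1 to compound 3 (0.20 log units; within the scatter) and a 1.8-fold lower number from compound 2 to compound 3 (0.25 log units; within the scatter). The entering group bears fluorine, as does the 2,4-difluorophenyl of compound 2, which reads 20200 nM, so a slight upward lean is reasonable. Within the data shown here, no measured compound carries trifluoromethyl, so the range stays wide.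

In this assay no change beyond the scatter is expected, and the estimated step is a 1.2-fold higher number from compound 3 to compound 4 (0.06 log units; within the scatter). For compound 4 the expected value is 13000 nM, with an estimated range of 5500 nM to 30000 nM.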

Compound 4, half-maximal inhibitory concentration: 8840 nM
Compound 4: middle estimate off by 1.5-fold (0.17 log units), on the high side, and the stated range covers the measured number.
By their numbers in this assay, from the lowest: compounds 1, 4, 3 and 2 (each within the scatter of the next, the first and the last beyond it).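

In this assay the 2-fluoro-5-(trifluoromethyl)phenyl group on the amide-type nitrogen stays level with the 2,6-diisopropylphenyl group in a 1.3-fold lower number from compound 3 to compound 4 (0.11 log units; within the scatter) and with the unsubstituted phenyl in a 1.2-fold higher number from compound 1 to compound 4 (0.10 log units; within the scatter), yet it stands apart from the 2,4-difluorophenyl group in a 2.3-fold lower number from compound 2 to compound 4 (0.36 log units; beyond the scatter). Fluorine on this aromatic ring therefore does not by itself go with a higher number: of the two fluorine-bearing groups, only the 2,4-difluorophenyl of compound 2 lies beyond the scatter from compound 1, and trifluoromethyl, new at this place, gives no step beyond the scatter from the phenyl. Nothing at hand accounts for the gap between the two fluorine-bearing groups.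

On these data alone, it remains open whether any group on this nitrogen can reach a lower number than compound 1 at 7090 nM by more than the scatter. A carboxylic acid, a morpholine or a plain alkyl chain in place of the aromatic ring would show whether that ring is needed here at all, and compound 4 alone cannot separate trifluoromethyl from the fluorine that enters with it.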